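The compounds below may be only part of what the source reports. "The series", "measured", "known", "first", "only" and "open" are said of these compounds alone.

Compound 1 `COc1cc2c(cc1OC)C(CC(N)=O)CC2` carries a plain amide with a hydrogen on its nitrogen. In a functional assay on the whole organism (strain Wistar) for inhibition, with Rattus norvegicus as the target, read by paw edema, with stated times of 60 min and 24 h, at a dose of 100 mg/kg by the oral route (a higher number here means more inhibition at the dose given (going by the name of the read-out), a lower number less inhibition), compound 1 gives 26.7%, the lowest of the three numbers measured, though only its distance to compound 3 lies beyond the scatter. Compound 2 `COc1cc2c(cc1OC)C(CC(=O)NC(C)C)CC2`, with an isopropyl on that nitrogen, gives 30% in this assay, and compound 3 `COc1cc2c(cc1OC)C(CC(=O)NC(C)(C)C)CC2`, with a tert-butyl there, gives 40%. The step of a number 3.3 percentage points higher from compound 1 to compound 2 (within the scatter) stays within the scatter, whereas a number 13.3 percentage points higher from compound 1 to compound 3 (beyond the scatter) is a modest gain beyond it; between the two larger groups, a number 10 percentage points higher from compound 2 to compound 3 (within the scatter) is again within the scatter.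

Compound 4 `COc1cc2c(cc1OC)C(CC(=O)NCc1ccccc1)CC2` has not yet been measured. It differs from compound 1 in one place: benzyl in place of hydrogen on an amide-type nitrogen. The two measured steps that replace this same amide hydrogen with a carbon group bear on it: the isopropyl gave a step within the scatter and the tert-butyl a modest gain. A further group on the same nitrogen is therefore expected to give, at best, a modest gain, and possibly nothing beyond the scatter. The expected step is a number 10.3 percentage points higher from compound 1 to compound 4 (beyond the scatter). Compound 4 is thus estimated to give 37%, with a likely range from 24% to 50%.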

Compound 4, a percentage reported as inhibition, in the whole organism at one dose (the size of the read-out at that dose, not a potency): 43.3%
Beside the measured number, compound 4's estimate is 6.3 percentage points below it; the measured number falls inside the stated range.
By their numbers in this assay, from the lowest: compounds 1, 2, 3 and 4 (each within the scatter of the next, the first and the last beyond it).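

Going by these compounds alone, on the amide-type nitrogen, benzyl is the only group so far that brings an aromatic ring, and in this assay it gives a number 16.6 percentage points higher from compound 1 to compound 4 (beyond the scatter) and so shows that this nitrogen can carry a ring as well as a branched chain without any loss of inhibition. Benzyl also gives a number 13.3 percentage points higher from compound 2 to compound 4 (beyond the scatter) and thus clears the scatter against isopropyl, which tert-butyl did not do, while a number 3.3 percentage points higher from compound 3 to compound 4 (within the scatter) means that benzyl and tert-butyl cannot be told apart at this dose, so two quite different groups read alike here. Nothing measured on these compounds explains these steps or why the two groups read alike.

From the compounds shown here alone, it remains open whether a phenylethyl group, with a longer chain before the ring, or a benzyl carrying a chlorine on its ring would separate from benzyl on this nitrogen. Also open, going by these compounds, are how an amine or a carboxylic acid at the end of the group on this nitrogen would read, and whether the steps seen at this single dose would hold at other doses.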